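Replacing a Sulfonyl Aryl Group with a Short Ester Chain

A few compounds are considered here, and "the series" means these few. Any claim that something is new, unique, unknown or untested is made for them only; others in the source may bear on it.

Compound 1 `CCN(CC)c1ccc2cc(C(=O)c3ccc(N4CCN(C(=O)CN5CCN(S(=O)(=O)c6ccc(C(F)(F)F)cc6)CC5)CC4)cc3)oc2c1` gives 32200 nM in a functional assay on HCT-116 cells (Homo sapiens) for cytotoxicity, read by MTT assay, with a stated time of 48 h; on this read-out lower numbers stand for stronger inhibition and higher numbers for weaker inhibition. Compound 2 `CCN(CC)c1ccc2cc(C(=O)c3ccc(N4CCN(C(=O)CN5CCN(S(=O)(=O)c6ccc(F)cc6)CC5)CC4)cc3)oc2c1` reaches only the limit of the assay in this assay, with > 40000 nM, so for compound 2 nothing more than a limit is known. Compound 3 `CCN(CC)c1ccc2cc(C(=O)c3ccc(N4CCN(C(=O)CN5CCN(Cc6ccc(/C=C/C(=O)OC)cc6)CC5)CC4)cc3)oc2c1` gives 9920 nM in this assay. Going by the values given here, the one measured step between close neighbours, an at least 1.2-fold higher number from compound 1 to compound 2 (0.09 log units; that floor lies within the scatter), is small and rests on a limit, because of the limit of > 40000 nM in this assay, at which 1 of the 3 values shown sits.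

Compound 4 `CCOC(=O)CN1CCN(CC(=O)N2CCN(c3ccc(C(=O)c4cc5ccc(N(CC)CC)cc5o4)cc3)CC2)CC1` differs from compound 2 by (ethoxycarbonyl)methyl in place of (4-fluorophenyl)sulfonyl on an amine nitrogen in a ring. Among the compounds with values here, this change removes the whole aromatic sulfonyl group rather than altering one substituent on it, so the single measured step, a swap of one aromatic substituent, bears on it only loosely. Within the data shown here, compound 3 shows that a different group at the same ring nitrogen can give a measurable number, but no direct step to it is available. The expected size of the change is therefore uncertain, with the estimated step of an at least 1.3-fold lower number from compound 2 to compound 4 (0.12 log units; that floor lies within the scatter). Compound 4 is estimated at 30000 nM, within 8000 nM to 80000 nM.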

Compound 4, half-maximal inhibitory concentration: > 40000 nM
Compound 4 gave a limit, no number; the forecaster's own chance of this, stated with the estimate: 40%; at least 1.3-fold (0.12 log units) between middle value and limit.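

Compound 4 gives > 40000 nM in this assay, which is a limit and not a number. Compound 2 also sits at a limit, so the step from it to compound 4 cannot be read, and swapping the sulfonyl group for the short ester chain has no measured size: the limit of > 40000 nM in this assay, at which 2 of the 4 values shown sit.

The comparison with compound 3 can be read: ethoxycarbonyl in place of 4-(2-(methoxycarbonyl)ethenyl)phenyl on the saturated chain carbon gives an at least 4.0-fold higher number from compound 3 to compound 4 (0.60 log units; beyond the scatter), so the group at this position does affect the read-out, and the short ester chain does worse here than the larger group of compound 3.

Still open, on these data alone, is whether the aromatic ring of compound 3 or its ester-bearing ethenyl chain matters more. A plain benzyl group on the same ring nitrogen, or a carboxylic acid in place of the ester of compound 4, would help to separate these.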